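The source may hold more compounds than are shown below. What is called first, only, known or untested is meant among the compounds shown, and "the series" means these compounds.

Of the compounds shown here, two of a shared core have been tested so far, and a third waits. Compound 1 `Cc1cccc(NNC(=O)c2cccc(NS(=O)(=O)c3cnc(O)nc3O)c2)c1` was run in a functional assay on OVCAR-3 cells (Homo sapiens) for antiproliferative activity, read by MTT assay, with a stated time of 24 h; a higher number here means a weaker inhibitor, a lower number a stronger inhibitor. In this assay compound 1 gives > 20000 nM, which is a limit of the assay rather than a measured number. Compound 2 `O=C(NNC(=O)c1ccc(NS(=O)(=O)c2cnc(O)nc2O)cc1)c1ccc(F)cc1` was run in the same way. In this assay compound 2 gives > 20000 nM, again a limit and not a number. Within the data shown here, compound 1 therefore stands at the limit, where every value shown sits (the limit of > 20000 nM in this assay, at which 2 of the 2 values shown sit), and no step between measured compounds can be read off, since neither of them yields a number.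

Compound 3 `O=C(NNC(=O)c1cccc(NS(=O)(=O)c2cnc(O)nc2O)c1)c1ccc(F)cc1` has not yet been tested. It differs from compound 1 in a single place: (4-fluorophenyl)carbonyl in place of 3-methylphenyl on an amine nitrogen. Compound 2 already carries the (4-fluorophenyl)carbonyl group and still gives only a limit, so no step beyond the scatter is expected from this change. The expected step is a step that the limit leaves unreadable from compound 1 to compound 3. Compound 3 is thus estimated at about 30000 nM, with a range from 15000 nM to 80000 nM, most probably reported again only as a limit.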

Compound 3, half-maximal inhibitory concentration: > 20000 nM
Compound 3: only a limit was reported (the forecaster's own chance of this, stated with the estimate: 85%); the middle value is on the limit's open side.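

No new step can be read between compound 1 and compound 3, since each of them gives only a limit of the assay and not a number: the limit of > 20000 nM in this assay, at which 3 of the 3 values shown sit.

The compounds shown leave open whether any compound of this shared core gives an actual number in this assay and how far (4-fluorophenyl)carbonyl in place of 3-methylphenyl would then move it.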